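A few compounds are considered here, and "the series" means these few. Any claim that something is new, unique, unknown or untested is made for them only; others in the source may bear on it.

Series notes. Compound 1 `CCCn1c(Br)nc2c(N)nc(NCc3ccccc3)nc21` and compound 2 `CCCn1c(Br)nc2c(N)nc(NCCCc3ccccc3)nc21` share one core, while compound 3 `CCCn1c(-c2ccco2)nc2c(NCc3ccccc3)ncnc21` and compound 4 `CCCn1c(-c2ccco2)nc2c(NCCCc3ccccc3)ncnc21` share another. The difference between the two cores is not broken down here.

In an assay on CHO cells for displacement of a labelled ligand from adenosine receptor A1 (Homo sapiens) (a lower number here means a stronger inhibitor, a higher number a weaker inhibitor), compound 1 gives 358 nM. In this assay compound 2 gives 583 nM. The change separating them, (phenethyl in place of phenyl on a saturated chain carbon bound to a nitrogen on an aromatic ring), produced a 1.6-fold higher number from compound 1 to compound 2 (0.21 log units; within the scatter). In this assay compound 3 gives 546 nM. Compound 3 and compound 2 lie within the scatter of each other, and so do compound 3 and compound 1, so no order among the three measured compounds is claimed.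

Compound 4 differs from compound 3 by phenethyl in place of phenyl on a saturated chain carbon bound to a nitrogen on an aromatic ring. This is the same change, in the same place, as that from compound 1 to compound 2; among the four compounds it occurs twice, and only one of the two instances is measured, on the other core, where its step fell within the scatter. For the measured compounds named here, the expectation for compound 4 rests on compound 3, whose value is 546 nM, and on the earlier step of a 1.6-fold higher number from compound 1 to compound 2 (0.21 log units; within the scatter), carried over as the only available guide. The expected step is a 1.6-fold higher number from compound 3 to compound 4 (0.19 log units; within the scatter). Going by the values given here, compound 4 is expected to give 850 nM in this assay, with a likely range from 350 nM to 2100 nM, the width reflecting the single precedent on a different core.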

Compound 4, inhibition constant: 378 nM
Compound 4: middle estimate off by 2.2-fold (0.35 log units), on the high side; the range from low to high includes it.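

In this assay, phenethyl in place of phenyl on a saturated chain carbon bound to a nitrogen on an aromatic ring gives a 1.4-fold lower number from compound 3 to compound 4 (0.16 log units; within the scatter), so on this core, as on the core of compound 1, the change produces no step beyond the scatter. The printed directions of the two steps are opposite, but the steps do not differ beyond what two such measurements allow: the same change on two cores in this assay, a 1.6-fold higher number (0.21 log units; within the scatter) from compound 1 to compound 2 and a 1.4-fold lower number (0.16 log units; within the scatter) from compound 3 to compound 4, 2.4-fold (0.37 log units) apart, within the scatter of two such steps

What this shows is limited: in these two matched pairs, going from benzyl to 3-phenylpropyl leaves the number within the scatter on either core, and the two cores give no measurable disagreement. It does not show that the change has no effect or the same effect on both cores, as two steps this small cannot settle the sign or size of any real effect, and two cores say nothing about a third.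

Still open, on these data alone, is whether any step beyond the scatter appears at this place with a longer chain than 3-phenylpropyl, or with a chain ending in an amine or a carboxylic acid instead of the phenyl ring. As far as these compounds go, the contribution of the difference between the two cores also remains open, as no single-place comparison separates its parts.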